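This account rests on a few compounds, and the source may have more. Where it says the series, first, only, none or still open, it means among the compounds named here.

Series notes. In a functional assay on A549 cells (Homo sapiens) for antiproliferative activity, read by MTT assay, with a stated time of 72 h (on this read-out lower numbers stand for stronger inhibition and higher numbers for weaker inhibition), compound 1 `O=C1NC(=O)/C(=C/C2=Cc3ccccc3OC2)N1` gives 29700 nM. Compound 2 `O=C(O)CN1C(=O)/C(=C/C2=Cc3ccccc3OC2)SC1=S` reaches only a limit of this assay, > 100000 nM. Compound 3 `O=C(O)CN1C(=O)/C(=C/C2=Cc3cc(Br)ccc3OC2)SC1=S` likewise reaches only a limit, > 25000 nM. The step that the two limits leave unreadable from compound 2 to compound 3 therefore sits between two limits, the limit of > 100000 nM in this assay, at which 1 of the 3 values shown sits, and (the limit of > 25000 nM in this assay, at which 1 of the 3 values shown sits), and its size cannot be read. Compound 3 thus stands on no number of its own in this assay, only on a limit, and of the three values shown two are limits and one is a number, that of compound 1.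

Compound 4 `CC1Oc2ccc(Br)cc2C=C1/C=C1\SC(=S)N(CC(=O)O)C1=O` differs from compound 3 by methyl in place of hydrogen on a saturated ring carbon. For the measured compounds named here, no measured step touches a change at this place; the single measured step, from compound 2 to compound 3, concerns another place and is not readable. Going by the values given here, nothing among the measured values therefore points to a move beyond the scatter in this assay. Compound 4 is expected to remain weak, at an estimated 40000 nM with a range of 12000 nM to 150000 nM, most likely again reported as a limit rather than a number. The step that the limit leaves unreadable from compound 3 to compound 4 is accordingly estimated as no change beyond the scatter.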

Compound 4, half-maximal inhibitory concentration: > 50000 nM
Compound 4 ended at the assay's limit; the forecaster's own chance of this, stated with the estimate: 70%; middle value at least 1.2-fold (0.09 log units) from the limit.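

For the compounds shown here, compound 4 reaches only a limit in this assay, > 50000 nM, as compound 3 does, and no step between compound 3 and compound 4 can be read. The compounds shown leave open whether methyl in place of hydrogen on a saturated ring carbon changes antiproliferative activity at all.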